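Swapping the piperazine on compound 1: a stability estimate

A few compounds are considered here, and "the series" means these few. Any claim that something is new, unique, unknown or untested is made for them only; others in the source may bear on it.

- Compound 1 `CN(C[C@H]1Cc2c(cccc2N2CCNC(C)(C)C2)CN1)[C@H]1CCCc2cccnc21`: 44%
- Compound 2 `FC1(F)CCC(CN(C[C@H]2Cc3c(cccc3N3CCNCC3)CN2)[C@H]2CCCc3cccnc32)CC1`: 76.6%

In an ADME assay on microsomes from liver (Mus musculus) for metabolic stability, read by LC-MS, with a stated time of 10 min (on this read-out higher numbers stand for a more stable compound and lower numbers for a less stable compound), compound 1 gives 44% as the lower of the two numbers, and the gap to compound 2 lies beyond the usual scatter, with compound 2 at 76.6% in this comparison. Compound 2 differs from compound 1 in more than one place. That gap cannot be tied to a single change.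

Compound 3 `C[C@@H]1CN(c2cccc3c2C[C@H](CN(C)[C@H]2CCCc4cccnc42)NC3)C[C@H](C)N1C` has not yet been measured. It keeps the core of compound 1 and carries one change: 3,4,5-trimethylpiperazin-1-yl in place of 3,3-dimethylpiperazin-1-yl on an aromatic carbon. Among the measured compounds shown here, no measured pair shows this swap alone. The expectation starts from compound 1 at 44% as its closest reference. The estimated a number 4 percentage points lower from compound 1 to compound 3 (within the scatter) is a slight fall that stays within the usual scatter. For compound 3 the expected value is 40% with an estimated range from 20% to 60% as the likely span.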

Compound 3, percent of the compound remaining: 39.6%
Beside the measured number, compound 3's estimate is 0.4 percentage points above it, and the stated range covers the measured number.
By their numbers in this assay, from the lowest: compounds 3 and 1 (each within the scatter of the next); then compound 2.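

Among the compounds shown here, the swap of 3,3-dimethylpiperazin-1-yl for 3,4,5-trimethylpiperazin-1-yl on an aromatic carbon gives the first reading of a single change at this position. In this assay the step is (a number 4.4 percentage points lower from compound 1 to compound 3 (within the scatter)). So the entering group, with 0 hydrogen-bond donors and 2 defined stereocentres, is tolerated here without a change in stability beyond the usual scatter, although the leaving group has 1 hydrogen-bond donor and the two groups differ in their substitution. No measurement shown gives a reason for this result.

As far as these compounds go, whether a morpholine, or a piperazine carrying an acetyl group, would also stay within the scatter at this place remains open. Also open, from the compounds shown here alone, is how much of the gap to compound 2 belongs to its piperazine and how much to its other differences.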